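A few compounds are considered here, and "the series" means these few. Any claim that something is new, unique, unknown or untested is made for them only; others in the source may bear on it.

Within the data shown here, compound 1 `Cn1c(Cc2nn(C)c(=O)c3ccccc23)nnc1SCC(=O)Nc1ccc(Cl)cc1Cl` is the only member of the series with a numerical value: in an assay on NK92 cells for inhibition of interleukin-15 (Homo sapiens), read by AlphaScreen, with stated times of 30 min and 1 h (on this read-out lower numbers stand for stronger inhibition and higher numbers for weaker inhibition), compound 1 gives 4500 nM. Compound 2 `Cn1nc(Cc2nnc(SCC(=O)Nc3ccc(Cl)cc3Cl)n2CCC(=O)O)c2ccccc2c1=O` is the other member. In this assay compound 2 reaches only a limit, > 30000 nM, so no number stands behind it. Among the measured compounds shown here, the step of an at least 6.6-fold higher number from compound 1 to compound 2 (0.82 log units; beyond the scatter) is the one measured change at this position. Compound 3 `Cn1c(Cc2nn(CCC=O)c(=O)c3ccccc23)nnc1SCC(=O)Nc1ccc(Cl)cc1Cl` differs from compound 1 by formylmethyl in place of hydrogen on a saturated chain carbon bound to an aromatic nitrogen, the same place that the carboxymethyl occupied in compound 2. The step to compound 2 bears directly on it; a weakening step a 2.7-fold higher number from compound 1 to compound 3 (0.43 log units; beyond the scatter) is therefore expected, though smaller than the limit suggests. Compound 3 is estimated at 12000 nM, between 4000 nM and 40000 nM.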

Compound 3, half-maximal inhibitory concentration: 20000 nM
Estimate against measurement, compound 3: 1.7-fold (0.22 log units) below; measured number inside the range.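

Formylmethyl in place of hydrogen on a saturated chain carbon bound to an aromatic nitrogen gives a 4.4-fold higher number from compound 1 to compound 3 (0.65 log units; beyond the scatter), so this change costs strength while still leaving a number that can be read. In this assay both changes from compound 1 shown so far raise the number, and no compound shown goes against this. Compound 2 remains a limit, not a number: the limit of > 30000 nM in this assay, at which 1 of the 3 values shown sits.

From the compounds shown here alone, whether an amine, a hydroxyl or a plain ethyl in this place would match compound 1 stays open. The compounds shown give no cause for the loss.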